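A few compounds are considered here, and "the series" means these few. Any claim that something is new, unique, unknown or untested is made for them only; others in the source may bear on it.

Cytotoxicity values recorded in a functional assay on MT4 cells (Homo sapiens) for cytotoxicity, read by CellTiter-Glo, with a stated time of 5 days; on this read-out higher numbers stand for an effect only at larger amounts of compound and lower numbers for an effect already at smaller amounts:

- compound 1 `Cc1ccc(-c2c(C)noc2C)cc1S(=O)(=O)NC1CCCC1`: 1590 nM
- compound 2 `Cc1noc(C)c1-c1cc(-c2c(C)noc2C)c2nc(C3CC3)[nH]c2c1`: 80 nM
- compound 3 `Cc1noc(C)c1-c1cc(-c2c(C)noc2C)c2cccnc2c1`: 897 nM

Compound 1 gives the highest of the three numbers. Its nearest neighbour is compound 3, whose value lies within the scatter of repeated measurement, so the two cannot be told apart on this read-out. Compound 2 lies well below compound 1, a gap beyond the scatter. For the measured compounds named here, no two of the three measured compounds differ in a single place, so no step between measured compounds can be read off.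

Compound 4 `Cc1ccc(-c2c(C)noc2CO)cc1S(=O)(=O)NC1CCCC1` is the next compound to be measured in this assay. Relative to compound 1 the change is hydroxy in place of hydrogen on a saturated chain carbon bound to an aromatic carbon. Going by the values given here, no measured pair carries this change, so the data give no direct guide to its effect. The step is estimated to be small, a 1.1-fold higher number from compound 1 to compound 4 (0.05 log units; within the scatter), with no move beyond the scatter expected in either direction. Compound 4 is expected to give 1800 nM, in the range 700 nM to 4500 nM.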

Compound 4, half-maximal effective concentration: 6820 nM
For compound 4 the middle estimate is 3.8-fold (0.58 log units) below the measured one; the whole stated range lies below it.
By their numbers in this assay, from the lowest: compound 2; then compounds 3 and 1 (each within the scatter of the next); then compound 4.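

In this assay, the series now has its first step at a single place: hydroxy in place of hydrogen on a saturated chain carbon bound to an aromatic carbon gives a 4.3-fold higher number from compound 1 to compound 4 (0.63 log units; beyond the scatter). This position is therefore not silent on this read-out, since the change from methyl to hydroxymethyl, a gain of one heavy atom, moves the effect to larger amounts of compound, beyond the scatter. Nothing measured here bears on why the number rises.

On these data alone, the step rests on one pair, so whether the same change gives a similar shift on the cores of compound 2 and compound 3 stays open. Also open, as far as these compounds go, is whether an amine, a carboxylic acid or a longer chain at this carbon would move the number further, or the other way.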